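The compounds below may be only part of what the source reports. "The series", "measured", "known", "first", "only" and "open" are said of these compounds alone.

Compound 1 `COC(=O)[C@@]1(C)CCC=C2[C@@H]1CC[C@@H](C)[C@]2(C)Cc1c[nH]c2ccc(Br)cc12` gives 15000 nM in a functional assay on A549 cells (Homo sapiens) for inhibition, read by sulforhodamine B assay, with a stated time of 48 h; a higher number here means a weaker inhibitor of growth, a lower number a stronger inhibitor of growth. Compound 2 `COC(=O)[C@@]1(C)CCC=C2[C@@H]1CC[C@@H](C)[C@]2(C)Cc1c[nH]c2ccc(C(F)(F)F)cc12` gives 15000 nM in this assay.

Among the measured compounds shown here, on the numbers so far compound 2 stands level with compound 1, as the step of no change at the digits printed from compound 1 to compound 2 (within the scatter) shows. Compound 3 `COC(=O)[C@@]1(C)CCC=C2[C@@H]1CC[C@@H](C)[C@]2(C)Cc1c(C)[nH]c2ccc(C(F)(F)F)cc12` differs from compound 2 by methyl in place of hydrogen on an aromatic carbon. For the measured compounds named here, no measured step involves such a change; the only measured step, no change at the digits printed from compound 1 to compound 2 (within the scatter), concerns a different group and lay within the scatter. With nothing pointing either way, the step of no change at the digits printed from compound 2 to compound 3 (within the scatter) in this assay is expected to stay within the scatter. Compound 3 is therefore estimated at 15000 nM, between 5000 nM and 45000 nM.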

Compound 3, concentration for 50% growth inhibition: 17000 nM
The estimate for compound 3 lay 1.1-fold (0.05 log units) below the measured number; the range from low to high includes it.
By their numbers in this assay, from the lowest: compounds 1, 2 and 3 (each within the scatter of the next).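

Methyl in place of hydrogen on this aromatic carbon, next to the ring nitrogen, gives a 1.1-fold higher number from compound 2 to compound 3 (0.05 log units; within the scatter) in this assay. So, at this position, compound 3 cannot be told apart from compound 2, and the added carbon shows no measurable effect on growth inhibition in these cells. No other measurement bears on this result.

Going by these compounds, whether a longer chain such as ethyl, or an amine, at this position would give a different number stays open. So does whether methyl here would give the same result alongside bromo instead of trifluoromethyl.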